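Notes on the step from compound 1 to compound 3

The source may report more compounds than this note shows. Statements on the series, on what has been measured and on what is new or still open speak of the compounds shown alone.

Measured so far in an ADME assay on Vero cells (Chlorocebus sabaeus) for cytotoxicity, read by MTT assay; a higher number here means a weaker inhibitor, a lower number a stronger inhibitor:
compound 1 `COc1ccc(-c2oc3c(CC=C(C)C)c(OC(C)C(=O)O)cc(O)c3c(=O)c2O)cc1`, 19300 nM
compound 2 `COc1ccc(-c2oc3c(CC=C(C)C)c(OC(C)C(=O)O)cc(O)c3c(=O)c2OC(C)C(=O)O)cc1`, "not determined" (no result reported); "not determined" (no result reported) (2 entries)

Among the compounds with values here, compound 1 gives 19300 nM, the only number. Within the data shown here, compound 2 has no result to compare with it, so compound 1 cannot be ranked and no measured step exists.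

Compound 3 `CCOC(=O)COc1cc(O)c2c(=O)c(O)c(-c3ccc(OC)cc3)oc2c1CC=C(C)C` keeps the shared core and differs from compound 1 at a single place, on an oxygen on an aromatic ring, with (ethoxycarbonyl)methyl in place of 1-carboxyethyl on an oxygen on an aromatic ring. Among the measured compounds shown here, no measured pair in this assay shows what this exchange does, so the anchor is compound 1 at 19300 nM alone and the expectation is loose. A modest move toward a lower number is expected, of a size not clearly beyond the scatter. The expected change is a 1.6-fold lower number from compound 1 to compound 3 (0.21 log units; within the scatter). The estimate for compound 3 is 12000 nM, with an expected range of 4000 nM to 40000 nM.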

Compound 3, half-maximal inhibitory concentration: 1400 nM
Compound 3: the middle estimate sits 8.6-fold (0.93 log units) above what was measured; the whole stated range lies above it.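

In this assay the exchange of 1-carboxyethyl for (ethoxycarbonyl)methyl on an oxygen on an aromatic ring gives a 14-fold lower number from compound 1 to compound 3 (1.14 log units; beyond the scatter) and so lies beyond the scatter. This shows that the group on this oxygen can move the read-out by a large step, which compound 1 alone, with compound 2 lacking a number, could not show. The exchange changes several things at once, from one hydrogen-bond donor to none and from one hydrogen-bond acceptor to two, and nothing at hand ties the step to any one of these changes or to any mechanism.

The compounds shown leave open which part of the exchange carries the step, since the ethyl ester and the altered carbon chain change together, and a carboxymethyl group on the same oxygen would separate the two. They also leave open whether a longer ester chain or an amine on this oxygen would continue the move toward a lower number, or whether this single step is all that the position offers in this series.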